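The compounds below may be only part of what the source reports. "The series", "measured", "known", "first", "only" and "open" are said of these compounds alone.

In an ADME assay on NL20 cells (Homo sapiens) for antiproliferative activity, read by MTT assay, with a stated time of 24 h (on this read-out lower numbers stand for stronger inhibition and higher numbers for weaker inhibition), compound 1 (`COc1cc(/C=C/C(=O)NNC(=O)c2ccccc2)cc(OC)c1O`) gives > 10000 nM as a limit and not a number. For the measured compounds named here, compound 2 (`COc1ccc(C(=O)NNC(=O)/C=C/c2cc(OC)c(O)c(OC)c2)cc1`) reads 9420 nM and is the only actual number so far. Going by the values given here, the one measured step, methoxy in place of hydrogen on an aromatic carbon, is an at least 1.0-fold lower number from compound 1 to compound 2 (0.02 log units; that floor lies within the scatter) and shows no size beyond the scatter. Compound 3 (`COc1cc(/C=C/C(=O)NNC(=O)c2ccc(O)cc2)cc(OC)c1O`) departs from compound 2 by hydrogen in place of methyl on an oxygen on an aromatic ring as hydrogen in place of methyl on an oxygen on an aromatic ring. Among the compounds with values here, no measured step covers this change. Within the data shown here, with only the step of an at least 1.0-fold lower number from compound 1 to compound 2 (0.02 log units; that floor lies within the scatter) as a guide, the expected 1.0-fold lower number from compound 2 to compound 3 (0.02 log units; within the scatter) stays within the scatter in this assay and has no firm direction. For compound 3 the estimate is 9000 nM with an expected range from 4500 nM to 20000 nM in this read-out.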

Compound 3, half-maximal inhibitory concentration: > 10000 nM
Compound 3 ended at the assay's limit (the forecaster's own chance of this, stated with the estimate: 45%); middle value at least 1.1-fold (0.04 log units) from the limit.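

Hydrogen in place of methyl on an oxygen on an aromatic ring gives an at least 1.0-fold higher number from compound 2 to compound 3 (0.02 log units; that floor lies within the scatter) in this assay, so methoxy to hydroxy at this place shows no size beyond the scatter. From the compounds shown here alone, compound 3 gives > 10000 nM, a limit and not a number, so the true size of this step stays unknown. The step for hydroxy in place of hydrogen cannot be read, and most of the series now sits at one limit: the limit of > 10000 nM in this assay, at which 2 of the 3 values shown sit.

Going by these compounds, whether an amine or a carboxylic acid in place of the methoxy of compound 2 reads differently stays open. Also open, on these data alone, is whether any group at this place gives a reading clearly beyond the scatter from compound 2.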